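Swapping the aryl group on compound 3's saturated ring carbon

The source may report more compounds than this note shows. Statements on the series, on what has been measured and on what is new or still open speak of the compounds shown alone.

Of the compounds shown here, three sharing one core have been measured in a functional assay on Ehrlich cells (Mus musculus) for cytotoxicity, read by trypan blue exclusion, with a stated time of 2 h, tested at 10 ug/mL; on this read-out higher numbers stand for a stronger effect at the one concentration tested and lower numbers for a weaker effect. Compound 1 `N#CC1=C(N)N(c2ccc(S(N)(=O)=O)cc2)C2=C(CCCC2)C1c1ccccc1` gives 5% in this assay. Compound 2 `Cc1ccc(C2C(C#N)=C(N)N(c3ccc(S(N)(=O)=O)cc3)C3=C2CCCC3)cc1` gives 20%, and compound 3 `COc1ccccc1C1C(C#N)=C(N)N(c2ccc(S(N)(=O)=O)cc2)C2=C1CCCC2` gives 30%. Compound 3 holds the highest of the three numbers; the step of a number 25 percentage points higher from compound 1 to compound 3 (beyond the scatter) lies beyond the scatter, whereas the step of a number 10 percentage points higher from compound 2 to compound 3 (within the scatter) lies within it, so compound 3 and compound 2 cannot be told apart on this read-out.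

Compound 4 `N#CC1=C(N)N(c2ccc(S(N)(=O)=O)cc2)C2=C(CCCC2)C1c1cccc([N+](=O)[O-])c1` is not yet measured. It differs from compound 3 in one place: 3-nitrophenyl in place of 2-methoxyphenyl on a saturated ring carbon

Two kinds of measured step speak to this change. The step of a number 10 percentage points higher from compound 2 to compound 3 (within the scatter) exchanged one aryl group for another on the same saturated ring carbon and stayed within the scatter. The steps of a number 15 percentage points higher from compound 1 to compound 2 (beyond the scatter) and a number 25 percentage points higher from compound 1 to compound 3 (beyond the scatter) show that adding a group to that aryl ring gave modest rises. Among the compounds with values here, no measured compound carries a 3-nitrophenyl group, so the direction is open. A step of a number 5 percentage points lower from compound 3 to compound 4 (within the scatter) in this assay is therefore expected, that is, no change beyond the scatter. Compound 4 is estimated to give 25%, within a range from 8% to 45%.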

Compound 4, a percentage reported as activity, at one concentration (the size of the read-out at that concentration, not a potency): 0%
Beside the measured number, compound 4's estimate is 25 percentage points above it; measured number below the stated range.
By their numbers in this assay, from the lowest: compounds 4 and 1 (each within the scatter of the next); then compounds 2 and 3 (each within the scatter of the next).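

In this assay, within the data shown here, this is the first exchange of aryl groups on the saturated ring carbon to move the number beyond the scatter, with a number 30 percentage points lower from compound 3 to compound 4 (beyond the scatter) and a number 20 percentage points lower from compound 2 to compound 4 (beyond the scatter), so the position does not accept every substituted aryl group equally. Set against the unsubstituted phenyl group of compound 1, the nitro group gives a number 5 percentage points lower from compound 1 to compound 4 (within the scatter), which shows that a group on this aryl ring does not raise the number by itself: methyl in compound 2 and methoxy in compound 3 went with rises, whereas nitro in compound 4 did not. No information is available here that explains why nitro parts from methyl and methoxy in this way.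

The 4-methylphenyl, 2-methoxyphenyl and 3-nitrophenyl groups differ both in the group they carry and in where it sits on the aryl ring, so the compounds shown cannot separate the identity of the group from its place. They also leave open how the number would respond to an amine or a carboxylic acid on that aryl ring, and whether the rises seen with methyl and methoxy extend to a longer chain or an ethoxy group.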